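The compounds below may be only part of what the source reports. "The series", "measured", "known", "first", "only" and "open" are said of these compounds alone.

Working notes on the series. Compound 1 `Cn1ccc2c(Oc3ccc(NC(=O)c4cc5cccnc5n(-c5ccc(F)c(Cl)c5)c4=O)cc3)ccnc21` in a functional assay on HT-29 cells (Homo sapiens) for antiproliferative activity, read by MTT assay, with a stated time of 72 h (on this read-out lower numbers stand for stronger inhibition and higher numbers for weaker inhibition), gives 1210 nM. Compound 2 `Cn1ccc2c(Oc3ccc(NC(=O)c4cc5cccnc5n(-c5ccc(Br)cc5F)c4=O)cc3)ccnc21` differs by 4-bromo-2-fluorophenyl in place of 3-chloro-4-fluorophenyl on an aromatic nitrogen and in this assay gives 2580 nM, a step of a 2.1-fold higher number from compound 1 to compound 2 (0.33 log units; beyond the scatter). Compound 3 `Cn1ccc2c(Oc3ccc(NC(=O)c4cc5cccnc5n(-c5ccc(F)c(Cl)c5)c4=O)cc3F)ccnc21` carries the core change fluoro in place of hydrogen on an aromatic carbon and in this assay gives 2460 nM, a step of a 2.0-fold higher number from compound 1 to compound 3 (0.31 log units; beyond the scatter). The values of compound 2 and compound 3 lie within the scatter of each other. Compound 4 `Cn1ccc2c(Oc3ccc(NC(=O)c4cc5cccnc5n(-c5ccc(Br)cc5F)c4=O)cc3F)ccnc21` is not yet measured; it differs from compound 3 by 4-bromo-2-fluorophenyl in place of 3-chloro-4-fluorophenyl on an aromatic nitrogen, the same change already seen between compound 1 and compound 2. If that step carries over onto the core of compound 3, the expected step is a 2.0-fold higher number from compound 3 to compound 4 (0.31 log units; beyond the scatter), resting on compound 1 to compound 2 showing a 2.1-fold higher number from compound 1 to compound 2 (0.33 log units; beyond the scatter). Compound 4 is therefore estimated at 5000 nM, with a range of 2500 nM to 10000 nM.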

Compound 4, half-maximal inhibitory concentration: 3290 nM
Beside the measured number, compound 4's estimate is 1.5-fold (0.18 log units) above it; the measured number falls inside the stated range.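

In this assay the change to 4-bromo-2-fluorophenyl gives a 1.3-fold higher number from compound 3 to compound 4 (0.13 log units; within the scatter), and this step cannot be told apart from the earlier one: the same change on two cores in this assay, a 2.1-fold higher number (0.33 log units; beyond the scatter) from compound 1 to compound 2 and a 1.3-fold higher number (0.13 log units; within the scatter) from compound 3 to compound 4, 1.6-fold (0.20 log units) apart, within the scatter of two such steps. The fluoro change gives a 1.3-fold higher number from compound 2 to compound 4 (0.11 log units; within the scatter), and the same holds for it: the same change on two cores in this assay, a 2.0-fold higher number (0.31 log units; beyond the scatter) from compound 1 to compound 3 and a 1.3-fold higher number (0.11 log units; within the scatter) from compound 2 to compound 4, 1.6-fold (0.20 log units) apart, within the scatter of two such steps. Both changes are thus consistent with carrying over between these two cores, but with only these four compounds and both new steps within the scatter, this does not show that either change has a real effect on the second core, nor that the steps are equal in size.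

Still open, on these data alone, is whether this holds with a chloro or a methoxy in place of the core fluoro, or with an unsubstituted phenyl on the aromatic nitrogen.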